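Swapping an amide-linked aryl for a sulfonyl-linked aryl

This account rests on a few compounds, and the source may have more. Where it says the series, first, only, none or still open, it means among the compounds named here.

Compound 3 `Cn1c(=O)c(C(=O)Nc2ccc(F)cc2F)cc2cnc(Nc3ccc4[nH]ccc4c3)nc21` gives 5000 nM in a functional assay on DU-145 cells (Homo sapiens) for inhibition, read by trypan blue exclusion, with a stated time of 72 h (on this read-out higher numbers stand for weaker inhibition and lower numbers for stronger inhibition), the second highest of the three numbers shown. Compound 1 `Cn1c(=O)c(S(=O)(=O)c2ccc(F)cc2[N+](=O)[O-])cc2cnc(Nc3ccc4[nH]ccc4c3)nc21` gives 1500 nM, and compound 2 `Cn1c(=O)c(S(=O)(=O)c2ccc(C(=O)O)cc2)cc2cnc(Nc3ccc4[nH]ccc4c3)nc21` gives 10000 nM; the change a 6.7-fold higher number from compound 1 to compound 2 (0.82 log units; beyond the scatter) shows how much the aryl group on the sulfonyl sulfur can matter. Compound 4 `Cn1c(=O)c(S(=O)(=O)c2ccc(F)cc2N)cc2cnc(Nc3ccc4[nH]ccc4c3)nc21` differs from compound 3 by (2-amino-4-fluorophenyl)sulfonyl in place of (2,4-difluorophenyl)carbamoyl on an aromatic carbon. No measured step covers this exact change, but compound 4 shares the sulfonyl link with compound 1, whose number is the lowest shown, and with compound 2. The number for compound 4 is therefore expected to fall between those of compound 1 and compound 2, with a step of a 2.5-fold lower number from compound 3 to compound 4 (0.40 log units; beyond the scatter) from compound 3, and is estimated at 2000 nM, within 500 nM to 8000 nM.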

Compound 4, half-maximal inhibitory concentration: 3000 nM
Compound 4: middle estimate off by 1.5-fold (0.18 log units), on the low side; low and high end bracket the measured number.
By their numbers in this assay, from the lowest: compounds 1, 4, 3 and 2 (each within the scatter of the next, the first and the last beyond it).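

In this assay, replacing the amide-linked aryl with a sulfonyl-linked aryl leaves the number within the usual scatter (a 1.7-fold lower number from compound 3 to compound 4 (0.22 log units; within the scatter)), so the two links cannot be told apart here. Amino in place of nitro on the sulfonyl-linked aryl is also within the scatter (a 2.0-fold higher number from compound 1 to compound 4 (0.30 log units; within the scatter)), while 2-amino-4-fluorophenyl in place of 4-carboxyphenyl gives a step beyond it (a 3.3-fold lower number from compound 2 to compound 4 (0.52 log units; beyond the scatter)). Nothing available explains these numbers. Still open, on these data alone, is whether a methoxy group in place of the amino, or a simple methyl on the sulfonyl sulfur in place of the aryl, would shift the number.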